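A few compounds are considered here, and "the series" means these few. Any claim that something is new, unique, unknown or untested is made for them only; others in the source may bear on it.

Compound 2 `CC1CCN(c2ccc3cc(NC(=O)CCc4ccc(C(F)(F)F)cc4)ccc3n2)C1` is measured in an assay on isolated protein for displacement of a labelled ligand from melanin-concentrating hormone receptor 1 (Homo sapiens) (a higher number here means a weaker inhibitor, a lower number a stronger inhibitor), where compound 2 gives 2 nM. Within the data shown here, of the two numbers known so far, its neighbour is compound 1 `O=C(CCc1ccc(C(F)(F)F)cc1)Nc1ccc2nc(N3CCC3)ccc2c1`, which in this assay gives 4 nM; the step of a 2.0-fold lower number from compound 1 to compound 2 (0.30 log units; within the scatter) lies within the scatter. Compound 3 `CC(C)C(=O)NC1CCN(c2ccc3cc(NC(=O)CCc4ccc(C(F)(F)F)cc4)ccc3n2)C1` carries (isopropylcarbonyl)amino in place of methyl on a saturated ring carbon. Among the measured compounds shown here, no measured step touches this part of the molecule, since the one known step swapped the whole saturated ring rather than a group on it, so it gives little guidance. The step of a 2.5-fold higher number from compound 2 to compound 3 (0.40 log units; beyond the scatter) is therefore only an expectation. Compound 3 is expected to give about 5 nM, with a range from 1.5 nM to 20 nM.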

Compound 3, half-maximal inhibitory concentration: 1 nM
Compound 3: the middle estimate sits 5.0-fold (0.70 log units) above what was measured, outside the stated range (below it).
By their numbers in this assay, from the lowest: compounds 3, 2 and 1 (each within the scatter of the next, the first and the last beyond it).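

In this assay, the saturated ring carbon accepts a much larger group: (isopropylcarbonyl)amino, with 6 heavy atoms against 1 for methyl, adds a hydrogen-bond donor and acceptor, yet the result is a 2.0-fold lower number from compound 2 to compound 3 (0.30 log units; within the scatter). Set against the azetidin-1-yl of compound 1, the 3-((isopropylcarbonyl)amino)pyrrolidin-1-yl group gives a 4.0-fold lower number from compound 1 to compound 3 (0.60 log units; beyond the scatter), a modest gain. No available evidence accounts for this tolerance. Going by these compounds, it remains open whether a free amine on that ring carbon would fit equally well, or a longer chain on the carbonyl.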